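The compounds below may be only part of what the source reports. "The series", "measured", "known", "first", "only" and "open" are said of these compounds alone.

For the measured compounds named here, in a functional assay on MCF7 cells (Homo sapiens) (a higher number here means a weaker inhibitor, a lower number a stronger inhibitor), two compounds that share one core have numbers so far. Compound 1 `COc1cc(NC(C)CCCNC(=O)NOCc2ccccc2)c2ncccc2c1` gives 9000 nM, while compound 2 `COc1cc(NC(C)CCCNC(=O)N(CCO)CCO)c2ncccc2c1` gives 36000 nM, the higher of the two numbers and so the weaker inhibitor of this pair. The next compound, compound 3 `CCOC(=O)NCCCC(C)Nc1cc(OC)cc2cccnc12`, keeps the shared core and differs from compound 2 at one place: ethoxy in place of bis(2-hydroxyethyl)amino on a carbonyl carbon. Going by the values given here, only one measured step bears on this change, since it swaps a group on the same carbonyl carbon: a 4.0-fold higher number from compound 1 to compound 2 (0.60 log units; beyond the scatter), a modest step beyond the scatter, with bis(2-hydroxyethyl)amino in place of (benzyloxy)amino. Ethoxy itself has no measurement yet, so this single step is a thin guide. On that evidence, leaving bis(2-hydroxyethyl)amino is expected to lower the number by a similarly modest amount, and the estimated step is a 2.6-fold lower number from compound 2 to compound 3 (0.41 log units; beyond the scatter). For compound 3 the expected value is about 14000 nM, with an estimated range from 4500 nM to 40000 nM.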

Compound 3, half-maximal inhibitory concentration: 26000 nM
Estimate against measurement, compound 3: 1.9-fold (0.27 log units) below; the measured number falls inside the stated range.
By their numbers in this assay, from the lowest: compound 1; then compounds 3 and 2 (each within the scatter of the next).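

At the carbonyl carbon in this assay, swapping bis(2-hydroxyethyl)amino for ethoxy gives a 1.4-fold lower number from compound 2 to compound 3 (0.14 log units; within the scatter) and so makes no readable difference. This holds even though the leaving group has 7 heavy atoms and 2 hydrogen-bond donors, while the entering group has 3 heavy atoms and 0 hydrogen-bond donors. The other new comparison is a 2.9-fold higher number from compound 1 to compound 3 (0.46 log units; beyond the scatter) and lies beyond the scatter, so (benzyloxy)amino now stands apart from two different groups at this place, not just one. Among these three compounds, then, the difference at this position comes from having (benzyloxy)amino there, and neither of the other two groups can be ranked against each other.

The compounds shown leave open whether a benzyloxy group or a simple methylamino group on the same carbonyl carbon would match compound 1 or fall with compound 2 and compound 3, and whether a longer chain in place of ethoxy would change the number at all. Nothing measured here explains why (benzyloxy)amino differs from the other two groups.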